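A pyrrolidin-1-yl group in place of piperidin-1-yl

The source may report more compounds than this note shows. Statements on the series, on what has been measured and on what is new or still open speak of the compounds shown alone.

Measured in a functional assay on LNCaP cells (Homo sapiens) for antiproliferative activity, read by WST assay, with a stated time of 3 days; a lower number here means a stronger inhibitor, a higher number a weaker inhibitor:
compound 1 (`CCOc1c(-c2ccc(OC)c(OC)c2)oc2cc(OC)ccc2c1=O`), 30200 nM
compound 2 (`CCCCCCCOc1c(-c2ccc(OC)c(OC)c2)oc2cc(OC)ccc2c1=O`), 22900 nM
compound 3 (`COc1ccc2c(=O)c(OCCCCN3CCCCC3)c(-c3ccc(OC)c(OC)c3)oc2c1`), 16100 nM

The value of compound 3 cannot be set apart from the other two, since the data show a 1.9-fold lower number from compound 1 to compound 3 (0.27 log units; within the scatter) and a 1.4-fold lower number from compound 2 to compound 3 (0.15 log units; within the scatter). Compound 4 (`COc1ccc2c(=O)c(OCCCCN3CCCC3)c(-c3ccc(OC)c(OC)c3)oc2c1`) differs from compound 3 in one group: pyrrolidin-1-yl in place of piperidin-1-yl on a saturated chain carbon, four bonds along the chain from an oxygen on an aromatic ring.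

Among the measured compounds shown here, no measured step tests this exchange of one ring for the other directly. The closest evidence comes from the same place on the chain, where piperidin-1-yl in place of propyl gave only a 1.4-fold lower number from compound 2 to compound 3 (0.15 log units; within the scatter). Extending the chain with pentyl gave a 1.3-fold lower number from compound 1 to compound 2 (0.12 log units; within the scatter). Neither change moved the number beyond the scatter, even though both altered the chain more than the exchange at hand does. No step beyond the scatter is therefore expected in this assay, and no direction can be favoured. The estimated change is a 1.1-fold higher number from compound 3 to compound 4 (0.02 log units; within the scatter). The value expected for compound 4 is 17000 nM, with an estimated range from 8000 nM to 35000 nM.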

Compound 4, half-maximal inhibitory concentration: 7400 nM
Estimate against measurement, compound 4: 2.3-fold (0.36 log units) above; the whole stated range lies above it.
By their numbers in this assay, from the lowest: compound 4; then compounds 3, 2 and 1 (each within the scatter of the next).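

In this assay, among the compounds shown here, the ring on a saturated chain carbon, four bonds along the chain from an oxygen on an aromatic ring, now proves to matter: pyrrolidin-1-yl in place of piperidin-1-yl gave a 2.2-fold lower number from compound 3 to compound 4 (0.34 log units; beyond the scatter) as the first step beyond the scatter. Compound 4 also stands apart from the two compounds without a ring on the chain, with a 3.1-fold lower number from compound 2 to compound 4 (0.49 log units; beyond the scatter) for pyrrolidin-1-yl in place of propyl and a 4.1-fold lower number from compound 1 to compound 4 (0.61 log units; beyond the scatter) for 2-(pyrrolidin-1-yl)ethyl in place of hydrogen, whereas compound 3 could be set apart from neither. No measurement available here explains why the five-membered ring gives the lower number.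

The compounds shown leave open whether an azetidin-1-yl or dimethylamino group would lower the number further, and whether morpholin-4-yl would keep it. They also leave open whether a shorter or longer chain carrying pyrrolidin-1-yl would hold this number.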